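Microsomal half-life notes: pyrazolyl to pyridinyl swap

The source may hold more compounds than are shown below. What is called first, only, known or untested is meant among the compounds shown, and "the series" means these compounds.

Measured so far in an ADME assay on microsomes from liver (Mus musculus) for metabolic stability, read by HPLC, using NADPH, with a stated time of 60 min, tested at 1 uM, in the presence of a further agent that is not named here; on this read-out lower numbers stand for a shorter-lived compound and higher numbers for a longer-lived compound:
- compound 1 `O=C(NNS(=O)(=O)c1ccccc1F)c1cc(F)cc(-n2cccn2)c1`: 0.0833 h
- compound 2 `O=C(NNS(=O)(=O)c1ccccc1F)c1cc(F)cc(-c2ccccn2)c1`: 0.217 h
- compound 3 `Cc1cc(-n2cccn2)cc(C(=O)NNS(=O)(=O)c2ccccc2)c1F`: 0.05 h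

Compound 1 and compound 2 share a core and differ by pyridin-2-yl in place of 1H-pyrazol-1-yl on an aromatic carbon. That change gave a 2.6-fold higher number from compound 1 to compound 2 (0.42 log units; beyond the scatter). Compound 3 stands lowest of the three numbers in this assay, but its gap to compound 1 lies within the scatter, so no order between compound 3 and compound 1 is claimed; only its gap to compound 2 is beyond the scatter. How the core of compound 3 differs from the core of compound 1 is not broken down here.

Compound 4 `Cc1cc(-c2ccccn2)cc(C(=O)NNS(=O)(=O)c2ccccc2)c1F` is not yet measured in this assay. It differs from compound 3 by pyridin-2-yl in place of 1H-pyrazol-1-yl on an aromatic carbon. This is the same kind of change as that from compound 1 to compound 2, though the surroundings differ: in compound 3 the site is meta to a methyl group and para to a fluoro group, whereas in compound 1 it is meta to a fluoro group. The step from compound 3 to compound 4 is expected to resemble the earlier one, a 2.6-fold higher number from compound 3 to compound 4 (0.41 log units; beyond the scatter), because compound 1 to compound 2 gave a 2.6-fold higher number from compound 1 to compound 2 (0.42 log units; beyond the scatter). Compound 4 is therefore estimated at 0.13 h, with a range from 0.06 h to 0.3 h.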

Compound 4, half-life in the Mus musculus assay: 0.0667 h
Compound 4: middle estimate off by 1.9-fold (0.29 log units), on the high side; the measured number falls inside the stated range.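

In the Mus musculus assay, the change on the core of compound 3 gave a 1.3-fold higher number from compound 3 to compound 4 (0.13 log units; within the scatter), so on this core alone it cannot be told from no change. Set beside the earlier step, the result shows no difference between the two cores, yet it does not establish that the earlier gain carries over, as only one of the two steps lies beyond the scatter: the same change on two cores in the Mus musculus assay, a 2.6-fold higher number (0.42 log units; beyond the scatter) from compound 1 to compound 2 and a 1.3-fold higher number (0.13 log units; within the scatter) from compound 3 to compound 4, 2.0-fold (0.29 log units) apart, within the scatter of two such steps. In a physicochemical assay for solubility, read by nephelometry, measured as kinetic solubility, at pH 2 (a lower number here means a less soluble compound, a higher number a more soluble compound), compound 3 gives 6.3 ug/mL and compound 4 gives 50 ug/mL. This only pair shown sits on the core of compound 3, so the rise in solubility speaks for that core alone: the measured solubility of compound 3, 6.3 ug/mL, and of compound 4, 50 ug/mL, a 7.9-fold higher number (0.90 log units; beyond the scatter).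

Within the data shown here, with only two matched pairs, it remains open whether the change behaves alike on other cores, or whether the half-life follows any consistent trend with it. Also open, going by these compounds, is how a different group on the same aromatic carbon, such as an amine or a carboxylic acid, would compare with 1H-pyrazol-1-yl and pyridin-2-yl on either read-out.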